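Ether chain change from compound 2 to compound 3

A few compounds are considered here, and "the series" means these few. Any claim that something is new, unique, unknown or untested is made for them only; others in the source may bear on it.

In a functional assay on A549 cells (Homo sapiens) for cytotoxicity, read by MTT assay, with a stated time of 72 h (a higher number here means a weaker inhibitor, a lower number a stronger inhibitor), compound 2 `CCOC1OC(=O)C(Cl)=C1Cl` gives 6300 nM, and compound 1 `CCCOC1OC(=O)C(Cl)=C1Cl` gives 3600 nM. For the measured compounds named here, these two values lie within the scatter of each other, so compound 2 stands level with its only measured neighbour.

Compound 3 `CC(C)(C)COC1OC(=O)C(Cl)=C1Cl` has tert-butyl in place of methyl on a saturated chain carbon bound to an oxygen on a saturated carbon.

Going by the values given here, only one measured step bears on this change: a 1.8-fold higher number from compound 1 to compound 2 (0.24 log units; within the scatter). That step stays within the scatter and sets no firm trend. Among the compounds with values here, no measured step covers tert-butyl, so the range is kept wide. No shift beyond the scatter is expected, and the expected step is a 1.6-fold lower number from compound 2 to compound 3 (0.20 log units; within the scatter). The estimated value for compound 3 is 4000 nM, with an expected range of 1500 nM to 10000 nM.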

Compound 3, half-maximal inhibitory concentration: 7700 nM
Compound 3: the middle estimate sits 1.9-fold (0.28 log units) below what was measured; the measured number falls inside the stated range.
By their numbers in this assay, from the lowest: compounds 1, 2 and 3 (each within the scatter of the next, the first and the last beyond it).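

Tert-butyl in place of methyl on a saturated chain carbon bound to an oxygen on a saturated carbon is accommodated in this assay without a shift beyond the scatter, with a 1.2-fold higher number from compound 2 to compound 3 (0.09 log units; within the scatter). Tert-butyl in place of ethyl at the same place gives the first step in the series beyond the scatter, though a modest one, with a 2.1-fold higher number from compound 1 to compound 3 (0.33 log units; beyond the scatter), so the three ethers span only a narrow range and none of the changes brings a gain over compound 1. Nothing measured on these compounds offers an explanation for either step.

As far as these compounds go, whether a longer straight chain, a cyclohexyl group or a chain carrying an amine or a carboxylic acid would move the number further remains open. Also open, from the compounds shown here alone, is whether any ether on the shared core can go clearly below compound 1.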